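The compounds below may be only part of what the source reports. "The series", "measured", "known", "first", "only" and "open" are said of these compounds alone.

Compound 1, `CCC/C(=C(/c1ccc(/C=C/C(=O)O)cc1)c1ccc2[nH]ncc2c1)c1ccccc1`: 11 nM
Compound 2, `O=C(O)/C=C/c1ccc(/C(=C(\c2ccc(C(F)(F)F)cc2Cl)C2CCC2)c2ccc3[nH]nc(F)c3c2)cc1`: 8.2 nM

Both numbers come from a functional assay on MCF7 cells (Homo sapiens) for cytotoxicity, read by CellTiter-Glo, with a stated time of 5 days; on this read-out higher numbers stand for weaker inhibition and lower numbers for stronger inhibition. Of the two, compound 2 gives the lower number, but its gap to compound 1 lies within the usual scatter of this kind of measurement, so the two compounds cannot be told apart on this evidence. Compound 3, `N#Cc1cc(Cl)cnc1/C(=C(\c1ccc(/C=C/C(=O)O)cc1)c1ccc2[nH]nc(F)c2c1)C1CCC1`, has not yet been measured. It differs from compound 2 in a single place: 5-chloro-3-cyanopyridin-2-yl in place of 2-chloro-4-(trifluoromethyl)phenyl on a double-bonded chain carbon bound to a double-bonded chain carbon and a saturated ring carbon. Among the measured compounds shown here, no pair of measured compounds shows a change of this kind, so there is no measured step to lean on, and the expectation rests on the change alone. The expected step is a 1.5-fold higher number from compound 2 to compound 3 (0.17 log units; within the scatter), which would not go beyond the scatter. On that basis compound 3 is estimated at 12 nM, with a range from 4 nM to 40 nM.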

Compound 3, half-maximal inhibitory concentration: 1.1 nM
The estimate for compound 3 lay 11-fold (1.04 log units) above the measured number; measured number below the stated range.
By their numbers in this assay, from the lowest: compound 3; then compounds 2 and 1 (each within the scatter of the next).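

The position on the double-bonded chain carbon bound to a double-bonded chain carbon and a saturated ring carbon proves sensitive to which ring it carries. In this assay, among the compounds shown here, placing 5-chloro-3-cyanopyridin-2-yl there instead of 2-chloro-4-(trifluoromethyl)phenyl gives a 7.5-fold lower number from compound 2 to compound 3 (0.87 log units; beyond the scatter) and this is a real difference, which compound 1 and compound 2 could not reveal because no single-place step linked them. The entering group has 2 hydrogen-bond acceptors against 0 for the group it replaces, but no measurement here accounts for the change in potency.

The ring nitrogen and the nitrile enter together, so this one step cannot show which of them matters, or whether losing the trifluoromethyl plays a part. From the compounds shown here alone, whether a 5-chloropyridin-2-yl group without the nitrile, or a primary amide in place of the nitrile, would keep the low number remains open.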